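The compounds below may be only part of what the source reports. "The series", "measured", "known", "first", "only" and "open" are said of these compounds alone.

In a functional assay on L02 cells (Homo sapiens) for inhibition, read by MTT assay, with a stated time of 48 h (on this read-out higher numbers stand for weaker inhibition and lower numbers for stronger inhibition), the measured compounds give:

Compound 1 `COc1ccc2c(=O)c(/C=C/C(=O)Nc3cccc(C)c3)coc2c1`: > 200000 nM, which is a limit of the assay and not a number.
Compound 2 `COc1ccc2c(=O)c(/C=C/C(=O)Nc3cccc(Cl)c3)coc2c1`: > 200000 nM, again a limit.
Compound 3 `COc1ccc(NC(=O)/C=C/c2coc3cc(OC)ccc3c2=O)cc1`: > 200000 nM, also a limit.

For the measured compounds named here, compound 3 therefore stands at the limit, and the two further values shown are limits as well, so no compound among the three can be placed above or below another; the picture is summed up by the limit of > 200000 nM in this assay, at which 3 of the 3 values shown sit. The compound still to be measured, compound 4 `COc1ccc2c(=O)c(/C=C/C(=O)Nc3ccccc3C)coc2c1`, differs from compound 3 in one place: 2-methylphenyl in place of 4-methoxyphenyl on an amide-type nitrogen. Going by the values given here, two measured steps touch the same position on the amide nitrogen, a step that the two limits leave unreadable from compound 1 to compound 3 and a step that the two limits leave unreadable from compound 2 to compound 3, and both are unreadable because the limit of > 200000 nM in this assay, at which 3 of the 3 values shown sit, leaves nothing to compare. The remaining step, a step that the two limits leave unreadable from compound 1 to compound 2, is unreadable for the same reason. Nothing measured shows that changing the aryl group on the amide nitrogen moves this read-out off the limit in either direction, so the expected step is a step that the limit leaves unreadable from compound 3 to compound 4, nothing beyond the scatter. Compound 4 is expected to give about 300000 nM, within 150000 nM to 600000 nM, most probably reported again only as a limit.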

Compound 4, half-maximal inhibitory concentration: > 200000 nM
Compound 4: no number, only a limit; the forecaster's own chance of this, stated with the estimate: 85%; the middle value is on the limit's open side.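

In this assay compound 4 gives > 200000 nM as a limit and not a number. For the compounds shown here, no step among compound 1, compound 2, compound 3 and compound 4 can be read: the limit of > 200000 nM in this assay, at which 4 of the 4 values shown sit.

The compounds shown leave open whether changing the aryl group on the amide-type nitrogen alters this assay at all, since none of them gives a number.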